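The source may hold more compounds than are shown below. What is called first, only, known or untested is meant among the compounds shown, and "the series" means these compounds.

Measured compounds:
- compound 1, `N#Cc1ccc(CN2c3ccccc3C(=O)N(Cc3ccccc3)S2(=O)=O)cc1`: 62000 nM
- compound 2, `O=C1c2ccccc2N(Cc2ccc(C(F)(F)F)cc2)S(=O)(=O)N1Cc1ccccc1`: 56000 nM
- compound 3, `O=C1c2ccccc2N(Cc2ccccc2Cl)S(=O)(=O)N1Cc1ccccc1`: 60000 nM

The numbers come from a functional assay on MRC5 cells (Homo sapiens); a lower number here means that less compound is tolerated, a higher number that more compound is tolerated. Compound 3 holds the second highest of the three numbers, and neither neighbour is set apart from it: the step of a 1.0-fold lower number from compound 1 to compound 3 (0.01 log units; within the scatter) and the step of a 1.1-fold higher number from compound 2 to compound 3 (0.03 log units; within the scatter) both stay inside the scatter. All three compounds share one core and differ only in the group carried on the saturated chain carbon bound to the sulfonamide nitrogen in the ring.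

Compound 4, `O=C1c2ccccc2N(Cc2cccc(Cl)c2)S(=O)(=O)N1Cc1ccccc1`, continues this same series. Its change from compound 3 is 3-chlorophenyl in place of 2-chlorophenyl on a saturated chain carbon bound to a sulfonamide nitrogen in a ring. The two steps that bear on this position, a 1.0-fold lower number from compound 1 to compound 3 (0.01 log units; within the scatter) and a 1.1-fold higher number from compound 2 to compound 3 (0.03 log units; within the scatter), show that rather different groups at this place left this assay unchanged beyond its scatter. No step beyond the scatter is therefore expected here either, in either direction. Compound 4 is thus expected to give about 60000 nM in this assay, somewhere between 30000 nM and 120000 nM, which means an expected step of no change at the digits printed from compound 3 to compound 4 (within the scatter).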

Compound 4, half-maximal cytotoxic concentration: 60000 nM
Compound 4: the middle estimate sits on the measured number at the digits printed; measured number inside the range.
By their numbers in this assay, from the lowest: compounds 2, 3, 4 and 1 (each within the scatter of the next).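

Putting 3-chlorophenyl in place of 2-chlorophenyl on the saturated chain carbon bound to the sulfonamide nitrogen in the ring changes nothing in this assay (no change at the digits printed from compound 3 to compound 4 (within the scatter)), so the same atoms joined differently matter as little here as the different groups compared earlier. Compound 4 also stays within the scatter of the two other compounds (a 1.1-fold higher number from compound 2 to compound 4 (0.03 log units; within the scatter); a 1.0-fold lower number from compound 1 to compound 4 (0.01 log units; within the scatter)), so all four compounds form one flat group in which none can be ranked above another. No measurement shown here explains why this position makes so little difference.

Still open, from the compounds shown here alone, is whether a carboxylic acid or an amine on this benzyl group, in place of the chlorine, would shift the number beyond the scatter. Going by these compounds, it is also open whether 4-chlorophenyl would fit the same flat picture.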